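The compounds below may be only part of what the source reports. "The series", "measured", "known", "first", "only" and "open" are said of these compounds alone.

Measured so far in a functional assay on RASMC cells (Rattus norvegicus) for inhibition, read by cell counting, with a stated time of 72 h; on this read-out lower numbers stand for stronger inhibition and higher numbers for weaker inhibition:
- compound 1, `CSCC[C@H](NC(=O)c1ccc(NC(=O)CCc2csc(N)n2)cc1-c1ccccc1C)C(=O)OC(C)C`: "not active" (no number reported)
- compound 2, `CSCC[C@H](NC(=O)c1ccc(NC(=O)CCc2csc(S)n2)cc1-c1ccccc1C)C(=O)OC(C)C`: 25000 nM

Among the measured compounds shown here, compound 2 carries the only number recorded in this assay; compound 1 is reported without a number, as not active. Compound 3, `CSCC[C@H](NC(=O)c1ccc(NC(=O)CCc2c[nH]c(S)n2)cc1-c1ccccc1C)C(=O)OC(C)C`, has not been measured. It differs from compound 2 by 2-sulfanyl-1H-imidazol-4-yl in place of 2-sulfanyl-1,3-thiazol-4-yl on a saturated chain carbon, two bonds along the chain from a carbonyl carbon. For the measured compounds named here, no step between measured compounds is available for this kind of exchange, so the expectation rests on compound 2 alone, which is weak at 25000 nM. A small move toward weaker inhibition, within or barely beyond scatter, is expected: the step from compound 2 to compound 3 is estimated at a 1.2-fold higher number from compound 2 to compound 3 (0.08 log units; within the scatter). Compound 3 is therefore expected near 30000 nM, ranging from 10000 nM to 100000 nM.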

Compound 3, half-maximal inhibitory concentration: 34000 nM
Compound 3: middle estimate off by 1.1-fold (0.05 log units), on the low side, and the stated range covers the measured number.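

In this assay, 2-sulfanyl-1H-imidazol-4-yl in place of 2-sulfanyl-1,3-thiazol-4-yl gives a 1.4-fold higher number from compound 2 to compound 3 (0.13 log units; within the scatter). At this saturated chain carbon, the read-out therefore does not separate the two rings, and both compounds stay in the same weak range. No measurement on hand accounts for this result.

Still open, on these data alone, is whether a phenyl or pyridine ring in place of these sulfanyl-bearing rings would move the number out of this range. As far as these compounds go, the effect of a longer chain between the ring and the carbonyl also remains open.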